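Exchanging the Amide Aryl Group of Compound 1

A few compounds are considered here, and "the series" means these few. Any claim that something is new, unique, unknown or untested is made for them only; others in the source may bear on it.

Compound 1, `O=C(Nc1ccc(Cl)c(-c2nnc3c(Cl)cccn23)c1)c1cccc(Cl)c1`, gives 30200 nM in a functional assay on T47D cells (Homo sapiens) for antiproliferative activity, read by MTT assay, with a stated time of 72 h; a higher number here means a weaker inhibitor, a lower number a stronger inhibitor.
Compound 2, `O=C(Nc1ccc(Cl)c(-c2nnc3c(Cl)cccn23)c1)c1ccon1`, reaches only a limit of the assay, > 100000 nM, in this assay.
Compound 3, `CS(=O)(=O)c1ccc(C(=O)Nc2ccc(Cl)c(-c3nnc4c(Cl)cccn34)c2)cc1`, likewise reaches only a limit, > 100000 nM, in this assay.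

Within the data shown here, compound 1 thus stands as the sole compound with a number; the other two sit at the limit of > 100000 nM in this assay, at which 2 of the 3 values shown sit. Compound 4, `O=C(Nc1ccc(Cl)c(-c2nnc3c(Cl)cccn23)c1)c1cccnc1`, differs from compound 1 by pyridin-3-yl in place of 3-chlorophenyl on a carbonyl carbon. The two measured steps that bear on an exchange at this carbonyl carbon both point the same way: an at least 3.3-fold higher number from compound 1 to compound 2 (0.51 log units; beyond the scatter) and an at least 3.3-fold higher number from compound 1 to compound 3 (0.51 log units; beyond the scatter). A further exchange at the same place is therefore expected to weaken inhibition in this assay again, so compound 4 is estimated at 100000 nM (range 30000 nM to 300000 nM), an expected step of a 3.3-fold higher number from compound 1 to compound 4 (0.52 log units; beyond the scatter).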

Compound 4, half-maximal inhibitory concentration: > 100000 nM
Compound 4: a limit, no number; the forecaster's own chance of this, stated with the estimate: 60%; the middle value sits exactly at the limit.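

The pyridin-3-yl group keeps a six-membered aromatic ring on the carbonyl carbon, yet the exchange still weakens inhibition in this assay, with an at least 3.3-fold higher number from compound 1 to compound 4 (0.51 log units; beyond the scatter). Holding that ring size is therefore not enough to keep a measurable value. Compound 1 remains the only compound with a number, and the steps among compound 2, compound 3 and compound 4 cannot be read, since each of these gives only a limit: the limit of > 100000 nM in this assay, at which 3 of the 4 values shown sit.

Going by these compounds, whether the chlorine or the carbon-only ring matters more stays open. A plain phenyl group would separate the two, and a 3-bromophenyl or 3-methoxyphenyl group would test other substituents there.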